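Ketone Side Chain Growth on a Glutamate Receptor Modulator Core

A few compounds are considered here, and "the series" means these few. Any claim that something is new, unique, unknown or untested is made for them only; others in the source may bear on it.

Compound 1 `COc1cc(C(=O)O)ccc1OCCCCOc1ccc(C(=O)C(C)C)c(O)c1C` gives 113 nM in an assay on HEK293 cells for positive allosteric modulation of metabotropic glutamate receptor 2 (Rattus norvegicus), read by thallium flux, with a stated time of 2.5 min; on this read-out higher numbers stand for an effect only at larger amounts of compound and lower numbers for an effect already at smaller amounts.
Compound 2 `COc1cc(C(=O)O)ccc1OCCCCOc1ccc(C(=O)CC(C)C)c(O)c1C` gives 40 nM in this assay.
Compound 3 `Cc1c(OCCCCOc2ccc(C(=O)O)cc2F)ccc(C(=O)CC(C)C)c1O` gives 102 nM in this assay.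

Compound 2 stands lowest of the three numbers: a 2.8-fold lower number from compound 1 to compound 2 (0.45 log units; beyond the scatter) and a 2.6-fold higher number from compound 2 to compound 3 (0.41 log units; beyond the scatter) both lie beyond the scatter, so it is the most potent of the measured set. Compound 4 `COc1cc(C(=O)O)ccc1OCCCCOc1ccc(C(=O)CC(C)(C)C)c(O)c1C` has not been measured. It differs from compound 2 by methyl in place of hydrogen on a saturated chain carbon bound to three saturated chain carbons. For the measured compounds named here, no measured pair repeats this exact change. The step that bears on it most closely is a 2.8-fold lower number from compound 1 to compound 2 (0.45 log units; beyond the scatter), which also grew the chain on the carbonyl carbon by one carbon and gave a modest gain. On these data alone, whether a further carbon at the branching point continues that trend, or reverses it, the three measured compounds cannot show; a step of modest size in either direction, or none beyond the scatter, all remain open. The expected change from compound 2 is therefore small, a 1.5-fold higher number from compound 2 to compound 4 (0.18 log units; within the scatter), with a wide band. Compound 4 is estimated at 60 nM in this assay, within a range from 20 nM to 180 nM.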

Compound 4, half-maximal effective concentration: 47 nM
Compound 4: the middle estimate sits 1.3-fold (0.11 log units) above what was measured, within the range that was stated.
By their numbers in this assay, from the lowest: compounds 2 and 4 (each within the scatter of the next); then compounds 3 and 1 (each within the scatter of the next).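

In this assay, the methyl that turns isobutyl into neopentyl on the carbonyl carbon brings no step beyond the scatter (a 1.2-fold higher number from compound 2 to compound 4 (0.07 log units; within the scatter)), so this saturated chain carbon bound to three saturated chain carbons carries the extra methyl without a readable change in the number. The advantage over the isopropyl compound also survives this branching, since neopentyl in place of isopropyl on the carbonyl carbon still gives a modest step beyond the scatter (a 2.4-fold lower number from compound 1 to compound 4 (0.38 log units; beyond the scatter)); growth of this side chain past isopropyl therefore holds for both the isobutyl and the neopentyl group, with no order between those two. Nothing given here explains why the added methyl leaves the number within the scatter.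

The compounds shown do not tell how a longer chain or a cyclohexyl group on the carbonyl carbon would read in this assay. For the compounds shown here, they also leave open whether fluoro in place of methoxy on the aromatic carbon, so far seen only with the isobutyl side chain, would give a similar step with the neopentyl group.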